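Turning the Side Chain Around on Compound 2

The source may hold more compounds than are shown below. What is called first, only, known or untested is meant among the compounds shown, and "the series" means these compounds.

In an ADME assay on HEK293 cells (Homo sapiens) for antiproliferative activity, read by MTT assay, with a stated time of 24 h (on this read-out higher numbers stand for weaker inhibition and lower numbers for stronger inhibition), compound 1 `COc1cc(C(=O)/C=C/c2cc(-c3cc(OC)c(OC)c(OC)c3)n3nc(-c4ccccc4)cc3n2)cc(OC)c1OC` reads >= 100000 nM as a limit of the assay and not as a number. Within the data shown here, compound 2 `COc1ccc(-c2cc(C(=O)/C=C/c3ccc(C)cc3)nc3cc(-c4ccccc4)nn23)cc1OC` gives 57400 nM as the only true number so far, which leaves it with no measured neighbour to be ranked against.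

The next compound to be read is compound 3 `COc1ccc(-c2cc(/C=C/C(=O)c3ccccc3)nc3cc(-c4ccccc4)nn23)cc1OC`. It keeps the core of compound 2 and differs in one place, on an aromatic carbon of a six-membered aromatic ring with 2 nitrogen. The change 2-benzoylethenyl in place of (2-(4-methylphenyl)ethenyl)carbonyl on an aromatic carbon puts 2-benzoylethenyl in place of (2-(4-methylphenyl)ethenyl)carbonyl, so the carbonyl and the ethenyl swap their order and the 4-methylphenyl gives way to an unsubstituted ring.

Among the measured compounds shown here, no measured step shows what such a swap does. For the measured compounds named here, with compound 2 at 57400 nM as the sole guide, no step beyond the scatter is expected in this assay and no clear direction can be assigned. The expected step of a 1.0-fold higher number from compound 2 to compound 3 (0.02 log units; within the scatter) is therefore small. Compound 3 is estimated at 60000 nM with an expected range from 25000 nM to 100000 nM when it is measured.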

Compound 3, half-maximal inhibitory concentration: 51200 nM
Beside the measured number, compound 3's estimate is 1.2-fold (0.07 log units) above it; the measured number falls inside the stated range.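

In this assay, the series now has its first measured step, a 1.1-fold lower number from compound 2 to compound 3 (0.05 log units; within the scatter), with 2-benzoylethenyl in place of (2-(4-methylphenyl)ethenyl)carbonyl on an aromatic carbon of the six-membered aromatic ring with 2 nitrogen. Among these compounds, this shows that, at this position, swapping the order of the carbonyl and the ethenyl while the 4-methylphenyl gives way to an unsubstituted ring does not move the read-out beyond the scatter, which the earlier compounds, with no step between them, could not show. Both changes sit in this one step, so neither can be read alone, and any separate effects they may have are not resolved; compound 1 gives a limit and not a number, and no step to it can be read: the limit of >= 100000 nM in this assay, at which 1 of the 3 values shown sits.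

Still open, from the compounds shown here alone, is whether the swap alone or the loss of the methyl alone would leave the read-out as it stands. Also open, going by these compounds, is what an amine or a carboxylic acid on the end ring of this side chain, or a longer chain between the carbonyl and that ring, would do at this position.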